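Sulfur for oxygen in the five-membered ring

The compounds below may be only part of what the source reports. "The series", "measured", "known", "first", "only" and "open" are said of these compounds alone.

Compound 1 `O=S(=O)(CC1=NCCO1)c1c(-c2ccccc2)nn(-c2ccccc2)c1-c1ccccc1` gives 59% in a functional assay, read by Griess assay, with a stated time of 150 min, tested at 75 ug/mL; on this read-out lower numbers stand for a weaker effect and higher numbers for a stronger effect at the one concentration tested. Compound 3 `Cc1ccc(C2CNN=C2S(=O)(=O)CC2=NCCO2)cc1` has a different core, and the difference between the two cores is not broken down here; in this assay compound 3 gives 49.7%. Compound 2 `Cc1ccc(C2CNN=C2S(=O)(=O)CC2=NCCS2)cc1` gives 48.6% in this assay. The change from compound 3 to compound 2 is a group of 5 heavy atoms (3 carbon, 1 nitrogen, 1 sulfur; one five-membered non-aromatic ring with 2 hetero atoms) in place of a group of 5 heavy atoms (3 carbon, 1 nitrogen, 1 oxygen; one five-membered non-aromatic ring with 2 hetero atoms), on a saturated chain carbon bound to a sulfonyl sulfur and made a step of a number 1.1 percentage points lower from compound 3 to compound 2 (within the scatter). Compound 4 `O=S(=O)(CC1=NCCS1)c1c(-c2ccccc2)nn(-c2ccccc2)c1-c1ccccc1` has not yet been measured in this assay; it differs from compound 1 by a group of 5 heavy atoms (3 carbon, 1 nitrogen, 1 sulfur; one five-membered non-aromatic ring with 2 hetero atoms) in place of a group of 5 heavy atoms (3 carbon, 1 nitrogen, 1 oxygen; one five-membered non-aromatic ring with 2 hetero atoms), on a saturated chain carbon bound to a sulfonyl sulfur, the same change at the same place. Within the data shown here, for compound 4 the expected step is a number 2 percentage points lower from compound 1 to compound 4 (within the scatter), because the only measured example of this change gave a number 1.1 percentage points lower from compound 3 to compound 2 (within the scatter). The estimate for compound 4 in this assay is therefore 57%, expected to fall between 45% and 69%.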

Compound 4, a percentage reported as activity, at one concentration (the size of the read-out at that concentration, not a potency): "not active" (no number reported)
No number was reported for compound 4; no gap can be computed for the estimate.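

Among these compounds, compound 4 is reported as not active in this assay with no number, so no step from compound 1 can be read. As far as these compounds go, whether the ring change behaves alike on both cores stays open. No evidence bears on this result.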